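Chloro to Methyl on the Trimethoxyphenyl Series

The compounds below may be only part of what the source reports. "The series", "measured", "known", "first", "only" and "open" are said of these compounds alone.

Four compounds stand side by side. Compound 1 `CCCc1nnc(SCC(=O)c2ccc(Cl)cc2)n1N1C(=O)c2ccccc2C1=O` and compound 2 `CCCc1nnc(SCC(=O)c2ccc(C)cc2)n1N1C(=O)c2ccccc2C1=O` carry propyl on the shared core, while compound 3 `COc1cc(-c2nnc(SCC(=O)c3ccc(Cl)cc3)n2N2C(=O)c3ccccc3C2=O)cc(OC)c1OC` and compound 4 `COc1cc(-c2nnc(SCC(=O)c3ccc(C)cc3)n2N2C(=O)c3ccccc3C2=O)cc(OC)c1OC` carry 3,4,5-trimethoxyphenyl in its place, a difference counted as 3,4,5-trimethoxyphenyl in place of propyl on an aromatic carbon. In a functional assay on MKN-45 cells (Homo sapiens) for cytotoxicity, read by MTT assay, with a stated time of 48 h (a lower number here means a stronger inhibitor, a higher number a weaker inhibitor), compound 1 gives > 200000 nM, which is a limit of the assay and not a number. Compound 2 gives > 200000 nM in this assay, again a limit. For the measured compounds named here, compound 3 gives 26600 nM in this assay, the only number among the three. Going by the values given here, the step of an at least 7.5-fold lower number from compound 1 to compound 3 (0.87 log units; beyond the scatter) is therefore the one readable change. The change methyl in place of chloro on an aromatic carbon made a step that the two limits leave unreadable from compound 1 to compound 2 because both values sit at the limit of > 200000 nM in this assay, at which 2 of the 3 values shown sit. The same change, (methyl in place of chloro on an aromatic carbon), now leads from compound 3 to compound 4, and the two places agree word for word, so it is the same change. With the earlier step unreadable, the expectation rests only on compound 3 and its value 26600 nM, and one expects a step of a 1.3-fold higher number from compound 3 to compound 4 (0.12 log units; within the scatter). Compound 4 is therefore estimated at 35000 nM in this assay, expected to fall between 12000 nM and 120000 nM.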

Compound 4, half-maximal inhibitory concentration: 9620 nM
Beside the measured number, compound 4's estimate is 3.6-fold (0.56 log units) above it, outside the stated range (below it).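

In this assay, methyl in place of chloro made a 2.8-fold lower number from compound 3 to compound 4 (0.44 log units; beyond the scatter), while the same change on the propyl core cannot be read, as both of its compounds stand at a limit of the assay and not at a number: the limit of > 200000 nM in this assay, at which 2 of the 4 values shown sit. The change is thus seen to lower the number on one core only, and the compounds shown neither confirm nor rule out the same step on the other. Trimethoxyphenyl in place of propyl made an at least 20-fold lower number from compound 2 to compound 4 (1.31 log units; beyond the scatter), and set beside the earlier step it gives this reading: the same change on two cores in this assay, an at least 7.5-fold lower number (0.87 log units; beyond the scatter) from compound 1 to compound 3 and an at least 20-fold lower number (1.31 log units; beyond the scatter) from compound 2 to compound 4; the limit leaves it open whether they differ.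

The compounds shown leave open what a fluoro, a methoxy or an amine would give in place of chloro or methyl on the same aromatic carbon. They also leave open whether a longer chain or an unsubstituted phenyl in place of propyl would give a readable number in this series.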